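From methoxycarbonyl to benzoyl on the shared core

A few compounds are considered here, and "the series" means these few. Any claim that something is new, unique, unknown or untested is made for them only; others in the source may bear on it.

Measured in an ADME assay on MCF7 cells (Homo sapiens) for inhibition (on this read-out higher numbers stand for weaker inhibition and lower numbers for stronger inhibition), all as limits:
Compound 1 `COC(=O)c1cc2c(F)c(F)c(Oc3ccccc3Br)c(F)c2s1`: > 25000 nM
Compound 2 `COC(=O)c1cc2c(F)c(F)c(Sc3ccccc3Br)c(F)c2s1`: > 25000 nM
Compound 3 `COC(=O)c1cc2c(F)c(F)c(Sc3ccc(C(C)(C)C)cc3)c(F)c2s1`: > 50000 nM

Compound 2 gives only a limit, > 25000 nM, and no number. Compound 4 `O=C(c1ccccc1)c1cc2c(F)c(F)c(Sc3ccccc3Br)c(F)c2s1` differs from it by phenyl in place of methoxy on a carbonyl carbon. Among the compounds with values here, the one measured step is a step that the two limits leave unreadable from compound 1 to compound 2, and it concerns a different group, so it offers no size to carry over. No step beyond the scatter is therefore expected in this assay, in either direction, and compound 4 may well report a limit too. For compound 4 the estimate is 30000 nM, expected between 10000 nM and 80000 nM. The expected change is a step that the limit leaves unreadable from compound 2 to compound 4.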

Compound 4, half-maximal inhibitory concentration: > 25000 nM
Compound 4 was reported as a limit; the forecaster's own chance of this, stated with the estimate: 70%; the middle value does not contradict the limit.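

In this assay compound 4 gives > 25000 nM, which is a limit. Compound 2 gives > 25000 nM, also a limit, so no step can be read from compound 2 to compound 4. The compounds shown leave open what actual concentration of any of them gives half-maximal inhibition in this assay.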